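Title: Moving from 3-methoxyphenyl to 2-fluorophenyl on the thiourea nitrogen

The source may hold more compounds than are shown below. What is called first, only, known or untested is meant among the compounds shown, and "the series" means these compounds.

Measured compounds:
compound 1, `Fc1cccc(NC(=S)N/N=C/c2ccc3ccccc3n2)c1`, 43800 nM
compound 2, `COc1cccc(NC(=S)N/N=C/c2ccc3ccccc3n2)c1`, 71200 nM
compound 3, `Cc1ccc(NC(=O)N/N=C/c2ccc3ccccc3n2)cc1`, > 100000 nM

In a functional assay on HL-60 cells (Homo sapiens) for antiproliferative activity, read by sulforhodamine B assay, with a stated time of 72 h (a higher number here means a weaker inhibitor, a lower number a stronger inhibitor), compound 2 gives 71200 nM. Compound 1 gives 43800 nM in this assay, and the step of a 1.6-fold higher number from compound 1 to compound 2 (0.21 log units; within the scatter) places the two numbers within the scatter of each other, so no order between compound 1 and compound 2 can be read from them. Compound 3 reaches only the limit of this assay, > 100000 nM, as noted by the limit of > 100000 nM in this assay, at which 1 of the 3 values shown sits.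

The unmeasured compound 4, `Fc1ccccc1NC(=S)N/N=C/c1ccc2ccccc2n1`, is reached from compound 2 by the change (2-fluorophenyl in place of 3-methoxyphenyl on an amide-type nitrogen). For the measured compounds named here, the one measured step that bears on this change is the exchange of fluoro for methoxy on the aromatic carbon, a 1.6-fold higher number from compound 1 to compound 2 (0.21 log units; within the scatter), which stayed within the scatter. Going by the values given here, on that basis no step beyond the scatter is expected in this assay from compound 2 to compound 4; the shift of the fluoro to the 2-fluorophenyl arrangement has no measured counterpart here, so the expectation remains loose. Compound 4 is therefore estimated at 50000 nM, with a range from 20000 nM to 120000 nM, which means an expected step of a 1.4-fold lower number from compound 2 to compound 4 (0.15 log units; within the scatter).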

Compound 4, half-maximal inhibitory concentration: > 100000 nM
Compound 4: no number, only a limit; the forecaster's own chance of this, stated with the estimate: 30%; middle value at least 2.0-fold (0.30 log units) away from the limit.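

In this assay compound 4 gives > 100000 nM, which is a limit of the assay and not a number. Exchanging 3-fluorophenyl for 2-fluorophenyl on the amide-type nitrogen gives an at least 2.2-fold higher number from compound 1 to compound 4 (0.35 log units; beyond the scatter), so with the fluoro kept, the choice between these two fluorophenyl groups does shift the result, which the step from fluoro to methoxy, within the scatter, did not show. Against the methoxy compound the same position gives an at least 1.4-fold higher number from compound 2 to compound 4 (0.14 log units; that floor lies within the scatter), and since that floor lies within the scatter, this step alone fixes no order, while only the comparison with compound 1 goes beyond it.

Going by these compounds, how far compound 4 truly lies from compound 1 stays unknown, as it now sits at the same ceiling as compound 3: the limit of > 100000 nM in this assay, at which 2 of the 4 values shown sit. Also open is whether an amine or a carboxylic acid on this phenyl ring, or a longer chain in its place on the amide-type nitrogen, would keep the number of compound 1 or move it in either direction.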